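The source may hold more compounds than are shown below. What is called first, only, known or untested is meant among the compounds shown, and "the series" means these compounds.

Compound 1 `CN1CCN(Cc2ccc(NC(=O)Nc3ccc4ncnc(Nc5cccc(C(F)(F)F)c5)c4c3)cc2)CC1` gives 2410 nM in a functional assay on A-431 cells (Homo sapiens) for antiproliferative activity, read by MTT assay, with a stated time of 72 h; on this read-out lower numbers stand for stronger inhibition and higher numbers for weaker inhibition.
Compound 2 `Cc1ccc(NC(=O)Nc2ccc3ncnc(Nc4cccc(C(F)(F)F)c4)c3c2)cc1` gives in this assay only > 10000 nM, which is a limit of the assay and not a number.

On the numbers shown, compound 2 stands only at a limit, as the limit of > 10000 nM in this assay, at which 1 of the 2 values shown sits, records. Among the measured compounds shown here, the one measured step, an at least 4.1-fold higher number from compound 1 to compound 2 (0.61 log units; beyond the scatter), is at least modest and beyond the scatter. The unmeasured compound 3 `CN1CCN(c2ccc(NC(=O)Nc3ccc4ncnc(Nc5cccc(C(F)(F)F)c5)c4c3)cc2)CC1` differs from compound 2 by 4-methylpiperazin-1-yl in place of methyl on an aromatic carbon. That measured step bears directly on this change: removing the 4-methylpiperazin-1-yl from a saturated chain carbon bound to an aromatic carbon gave the higher number, and here the same group returns, now on an aromatic carbon of the ring. A lower number is therefore expected for compound 3 in this assay, a step of about an at least 3.3-fold lower number from compound 2 to compound 3 (0.52 log units; beyond the scatter). Compound 3 is estimated to give 3000 nM, with a range from 900 nM to 10000 nM.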

Compound 3, half-maximal inhibitory concentration: 2200 nM
For compound 3 the middle estimate is 1.4-fold (0.13 log units) above the measured one; the range from low to high includes it.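

In this assay, 4-methylpiperazin-1-yl in place of methyl on the aromatic carbon gives an at least 4.5-fold lower number from compound 2 to compound 3 (0.65 log units; beyond the scatter), so the group also goes with the lower number when it sits directly on the ring, not only when a saturated chain carbon carries it. Removing that chain carbon gives a 1.1-fold lower number from compound 1 to compound 3 (0.04 log units; within the scatter), so these values do not tell the two attachments apart. The full size of the first step stays unknown, since compound 2 stands at a limit of the assay and not at a number: the limit of > 10000 nM in this assay, at which 1 of the 3 values shown sits.

As far as these compounds go, it remains open whether another amine at this place, such as a morpholine ring or a dimethylamino group, would go with the same lower number, or whether a carboxylic acid would. A longer chain linking the ring to the 4-methylpiperazin-1-yl also remains untested in the compounds shown.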